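The source may report more compounds than this note shows. Statements on the series, on what has been measured and on what is new or still open speak of the compounds shown alone.

Compound 1, `O=C(O)CCCCc1cnc(C(=O)CCCCCCc2ccccc2)o1`: 23.8 nM
Compound 2, `CSC(=O)CCCCc1cnc(C(=O)CCCCCCc2ccccc2)o1`: 1.8 nM
Compound 3, `N#CCCCCCc1cnc(C(=O)CCCCCCc2ccccc2)o1`: 4.8 nM

These three compounds share one core and differ only in the group at the end of a saturated chain. In an assay for inhibition of Fatty-acid amide hydrolase 1 (Rattus norvegicus), using a Dixon plot (a lower number here means a stronger inhibitor, a higher number a weaker inhibitor), compound 1 gives 23.8 nM, compound 2 gives 1.8 nM, and compound 3 gives 4.8 nM. Compound 3 therefore stands between the other two: its number is the second highest of the three, a 2.7-fold higher number from compound 2 to compound 3 (0.43 log units; beyond the scatter), while a 5.0-fold lower number from compound 1 to compound 3 (0.70 log units; beyond the scatter).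

Compound 4, `O=C(CCCCCCc1ccccc1)c1ncc(CCCCCCl)o1`, has not yet been measured. It differs from compound 3 by a single exchange: chloro in place of cyano on a saturated chain carbon, five bonds along the chain from an aromatic carbon. The measured steps that bear on this are the two that also swap the end group of that chain, namely a 13-fold lower number from compound 1 to compound 2 (1.12 log units; beyond the scatter) and a 5.0-fold lower number from compound 1 to compound 3 (0.70 log units; beyond the scatter). Both of these were beyond the scatter, one large and one modest, so an exchange at this position can clearly move the number. For the measured compounds named here, no chloro analogue has been measured, so the direction rests on judgement alone. The expected outcome is a modest step, a 1.7-fold higher number from compound 3 to compound 4 (0.22 log units; within the scatter), toward a slightly weaker inhibitor. Compound 4 is thus estimated at 8 nM, with a range from 2.5 nM to 25 nM.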

Compound 4, inhibition constant: 5.2 nM
The estimate for compound 4 lay 1.5-fold (0.19 log units) above the measured number; low and high end bracket the measured number.
By their numbers in this assay, from the lowest: compound 2; then compounds 3 and 4 (each within the scatter of the next); then compound 1.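

In this assay, exchanging the cyano group for chloro makes no readable difference (a 1.1-fold higher number from compound 3 to compound 4 (0.03 log units; within the scatter)), so at this chain end a single chlorine atom, with no hydrogen-bond acceptor, matches a cyano group with a triple bond and one hydrogen-bond acceptor. Compound 4 also has the same standing against the other two end groups as compound 3: the methylsulfanyl carbonyl end still gives the lower number (a 2.9-fold higher number from compound 2 to compound 4 (0.46 log units; beyond the scatter)), and the carboxy end still gives the higher one (a 4.6-fold lower number from compound 1 to compound 4 (0.66 log units; beyond the scatter)). No measurement shown here accounts for the close match between the cyano and chloro end groups.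

The compounds shown leave open whether a bromo group, a hydroxy group or an amine at the same chain end would give a number close to those of compound 3 and compound 4, or would instead move toward compound 1 or compound 2. They also leave open whether the match between chloro and cyano would survive on a shorter or longer chain, since the chain length at this end barely varies across these four compounds.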